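The compounds below may be only part of what the source reports. "The series", "measured", "known", "first", "only" and "open" are said of these compounds alone.

Measured so far:
Compound 1, `Cc1cc(Nc2ccn(Cc3nc(C)c4ccccc4n3)n2)n2nc(SCc3ccc(Br)cc3)nc2n1` — in a functional assay on MGC-803 cells (Homo sapiens) for inhibition, read by MTT assay, with a stated time of 72 h (a higher number here means a weaker inhibitor, a lower number a stronger inhibitor), compound 1 gives 960 nM.
Compound 2, `Cc1cc(Nc2cc(-c3ccccc3)[nH]n2)n2nc(SCCc3ccccc3)nc2n1` — in this assay compound 2 gives 5620 nM.

Of the two numbers recorded, compound 2 has the higher one, and the gap between compound 2 and compound 1 lies beyond the usual scatter, so compound 2 is the weaker inhibitor of the pair. The two compounds differ in several places at once, so no single change can be read from that gap.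

Compound 3, `Cc1cc(Nc2cc(-c3ccccc3)[nH]n2)n2nc(SCC(=O)c3ccccc3)nc2n1`, has not yet been measured. It differs from compound 2 in one place: benzoyl in place of benzyl on a saturated chain carbon bound to a sulfur. Within the data shown here, no pair among the measured compounds isolates this change, so there is nothing in the data to say which way it should move the number. The step from compound 2 to compound 3 is therefore expected to stay within the scatter, a 1.2-fold lower number from compound 2 to compound 3 (0.10 log units; within the scatter), with no clear direction. On that basis compound 3 is estimated at 4500 nM in this assay, within a range of 1500 nM to 15000 nM.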

Compound 3, half-maximal inhibitory concentration: 2580 nM
Estimate against measurement, compound 3: 1.7-fold (0.24 log units) above; measured number inside the range.
By their numbers in this assay, from the lowest: compound 1; then compound 3; then compound 2.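

Among these compounds, the change on the saturated chain carbon bound to a sulfur now has its first reading: in this assay, benzoyl in place of benzyl gives a 2.2-fold lower number from compound 2 to compound 3 (0.34 log units; beyond the scatter) and this modest step is the first effect that can be tied to one place. Until now the only measured pair differed in several places at once, so nothing had shown that this position alone could move the number. The pair also shows that the carbonyl of benzoyl, which brings the one hydrogen-bond acceptor counted for that group, goes with a stronger inhibitor here rather than a weaker one, and no measurement at hand says why this step occurs.

On these data alone, what stays open is whether the step belongs to the carbonyl itself, which a hydroxyl or an amide on the same chain would help to settle, or whether a longer chain between the sulfur and the ring would shift the number further. A single pair also leaves open whether the same change would carry over to the differently substituted compound 1.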